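This account rests on a few compounds, and the source may have more. Where it says the series, first, only, none or still open, it means among the compounds named here.

Measured in an assay on liver for inhibition of sterol O-acyltransferase 1 (Rattus norvegicus), using microsomes; on this read-out lower numbers stand for stronger inhibition and higher numbers for weaker inhibition: compound 1 `CC(C)c1cccc(C(C)C)c1NC(=O)NS(=O)(=O)N1CCCC1` gives 15000 nM; compound 2 `CCCCCCNS(=O)(=O)NC(=O)Nc1c(C(C)C)cccc1C(C)C` gives 8100 nM.

Compound 2 has only compound 1 as a neighbour, and the step of a 1.9-fold lower number from compound 1 to compound 2 (0.27 log units; within the scatter) lies within the scatter, so the two numbers are not separated. Compound 3 `CC(C)c1cccc(C(C)C)c1NC(=O)NS(=O)(=O)N(C(C)C)C(C)(C)C` differs from compound 2 by isopropyl(tert-butyl)amino in place of hexylamino on a sulfonyl sulfur. Among the measured compounds shown here, the only measured step at this sulfonyl sulfur, a 1.9-fold lower number from compound 1 to compound 2 (0.27 log units; within the scatter), stayed within the scatter, and no step involving an isopropyl(tert-butyl)amino group has been measured. No change beyond the scatter is therefore expected in this assay. For compound 3 the estimate is 9000 nM, range 3000 nM to 30000 nM, which is expected to mean a 1.1-fold higher number from compound 2 to compound 3 (0.05 log units; within the scatter).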

Compound 3, half-maximal inhibitory concentration: 140 nM
The estimate for compound 3 lay 64-fold (1.81 log units) above the measured number; measured number below the stated range.
By their numbers in this assay, from the lowest: compound 3; then compounds 2 and 1 (each within the scatter of the next).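

The sulfonyl sulfur position, where nothing had separated before, responds strongly in this assay with a 58-fold lower number from compound 2 to compound 3 (1.76 log units; beyond the scatter) and a 110-fold lower number from compound 1 to compound 3 (2.03 log units; beyond the scatter) when isopropyl(tert-butyl)amino is the group on the sulfur. Both steps lie beyond the scatter, so this group stands apart from hexylamino and pyrrolidin-1-yl, which remain unseparated from each other. No available evidence bears on the reason for this gain.

As far as these compounds go, whether the isopropyl part, the tert-butyl part or their combination carries the gain remains open. So does the role of the amino hydrogen of hexylamino, which tert-butylamino and diisopropylamino on the same sulfur would help to separate.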